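Cytotoxicity of the amide-nitrogen aryl variants

The compounds below may be only part of what the source reports. "The series", "measured", "known", "first", "only" and "open" are said of these compounds alone.

Compound 1 `COc1ccc([C@H]2CC(=O)N(c3ccc(N)cc3)C2)cc1OC1CCCC1` is tested in a functional assay on HEK293 cells (Homo sapiens) for cytotoxicity; a higher number here means that more compound is tolerated, a lower number that less compound is tolerated. Compound 1 gives only the limit > 10000 nM. Compound 2 `COc1ccc([C@H]2CC(=O)N(c3cc(N)cc(F)c3)C2)cc1OC1CCCC1` likewise reaches only the limit > 10000 nM. Compound 3 `COc1ccc([C@H]2CC(=O)N(c3ccc(C)cc3)C2)cc1OC1CCCC1` also stops at the limit > 10000 nM. Compound 1 therefore stands at the limit of > 10000 nM in this assay, at which 3 of the 3 values shown sit, and the steps a step that the two limits leave unreadable from compound 1 to compound 2, a step that the two limits leave unreadable from compound 1 to compound 3 and a step that the two limits leave unreadable from compound 2 to compound 3 cannot be sized.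

Compound 4 `COc1ccc([C@H]2CC(=O)N(c3ccncc3)C2)cc1OC1CCCC1` differs from compound 1 as pyridin-4-yl in place of 4-aminophenyl on an amide-type nitrogen in a ring. Among the measured compounds shown here, no measured step bears directly on this change; every exchange of the aryl group on the amide-type nitrogen in a ring so far ended at the limit. No step beyond the scatter is therefore expected in this assay. Compound 4 is expected to show 15000 nM, within 8000 nM and 40000 nM, most likely again only as a limit. The expected step that the limit leaves unreadable from compound 1 to compound 4 is thus essentially none.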

Compound 4, half-maximal cytotoxic concentration: > 10000 nM
Compound 4: a limit, no number; the forecaster's own chance of this, stated with the estimate: 85%; the middle value is on the limit's open side.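

No step from compound 4 to compound 1, compound 2 or compound 3 can be read, since all four compounds give only a limit: the limit of > 10000 nM in this assay, at which 4 of the 4 values shown sit.

The compounds shown leave open whether these aryl exchanges on the amide-type nitrogen make any difference in this assay.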